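The compounds below may be only part of what the source reports. "The series", "measured", "known", "first", "only" and "open" are said of these compounds alone.

Values in a functional assay on HepG2 cells (Homo sapiens) for antiproliferative activity, read by CCK-8 assay, with a stated time of 48 h; on this read-out lower numbers stand for stronger inhibition and higher numbers for weaker inhibition:
- compound 1 `COc1ccc(/C=C\c2cc(OC)c(OC)c(OC)c2)cc1OCc1ccc(CN2C[C@H](O)C[C@@H]2C(=O)O)cc1`: > 10000 nM, a limit of the assay
- compound 2 `COc1ccc(/C=C\c2cc(OC)c(OC)c(OC)c2)cc1OCc1ccc(CNCCO)cc1`: 5900 nM
- compound 3 `COc1ccc(/C=C\c2cc(OC)c(OC)c(OC)c2)cc1OCc1ccc(CN2CCCCC2C(=O)NCCNC(=O)OC(C)(C)C)cc1`: 1100 nM

Of the two actual numbers, compound 2 holds the higher, and compound 3 lies lower, beyond the scatter. Next is compound 4 `COc1ccc(/C=C\c2cc(OC)c(OC)c(OC)c2)cc1OCc1ccc(CN2CC[C@@H](C(=O)O)C2)cc1`, which differs from compound 2 by 3-carboxypyrrolidin-1-yl in place of (2-hydroxyethyl)amino on a saturated chain carbon bound to an aromatic carbon. Among the measured compounds shown here, the one measured step bearing on this change is an at least 1.6-fold lower number from compound 1 to compound 2 (0.22 log units; that floor lies within the scatter). It runs the opposite way at the same place and starts from a limit, so it is only a loose guide. Compound 4 carries a carboxypyrrolidine like compound 1, without the hydroxy group. The expected step in this assay is a 1.5-fold higher number from compound 2 to compound 4 (0.18 log units; within the scatter), towards weaker inhibition, and a limit is a real possibility. For compound 4 the estimate is 9000 nM, with an expected range of 4000 nM to 20000 nM.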

Compound 4, half-maximal inhibitory concentration: 2300 nM
Compound 4: middle estimate off by 3.9-fold (0.59 log units), on the high side; the measured number lies below the stated range.
By their numbers in this assay, from the lowest: compound 3; then compound 4; then compound 2. At a limit, above all of these: compound 1.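

In this assay, 3-carboxypyrrolidin-1-yl in place of (2-hydroxyethyl)amino gives a 2.6-fold lower number from compound 2 to compound 4 (0.41 log units; beyond the scatter), so a carboxypyrrolidine on this saturated chain carbon does not by itself bring the series to the limit. In place of 2-carboxy-4-hydroxypyrrolidin-1-yl, the same group gives an at least 4.3-fold lower number from compound 1 to compound 4 (0.63 log units; beyond the scatter). That step starts from compound 1, whose value is a limit: the limit of > 10000 nM in this assay, at which 1 of the 4 values shown sits.

Compound 1 and compound 4 differ in both the hydroxy group and the place of the carboxy group, and the two changes cannot be separated here. Going by these compounds, whether a methyl ester or primary amide in place of the carboxylic acid would hold this level also remains open.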